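The compounds below may be only part of what the source reports. "The series", "measured", "known", "first", "only" and "open" are said of these compounds alone.

Measured so far:
Compound 1 `O=C1O/C(=C\Cn2cc(-c3cc(F)cc(F)c3)nn2)C(OCc2ccccc2)=C1OCc1ccccc1`: in a functional assay on A549 cells (Homo sapiens) for antiproliferative activity, read by MTT assay, with a stated time of 72 h (on this read-out higher numbers stand for weaker inhibition and lower numbers for stronger inhibition), compound 1 gives > 100000 nM, a limit of the assay, not a number.
Compound 2 `O=C1O[C@H]([C@@H](O)Cn2cc(CNS(=O)(=O)c3ccc(F)cc3)nn2)C(OCc2ccccc2)=C1OCc1ccccc1`: in this assay compound 2 gives 22500 nM.
Compound 3 `O=C1O/C(=C\Cn2cc(-c3ccc(Br)cc3)nn2)C(OCc2ccccc2)=C1OCc1ccccc1`: in this assay compound 3 gives > 100000 nM, again a limit of the assay.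

Within the data shown here, compound 2 is thus the only member with a number in this assay; the other two sit at the limit of > 100000 nM in this assay, at which 2 of the 3 values shown sit. Among the measured compounds shown here, the single measured step, a step that the two limits leave unreadable from compound 1 to compound 3, runs between two limits and its size cannot be read. Compound 4 `O=C1O[C@H]([C@@H](O)Cn2ccnn2)C(OCc2ccccc2)=C1OCc1ccccc1` differs from compound 2 by hydrogen in place of (((4-fluorophenyl)sulfonyl)amino)methyl on an aromatic carbon. For the measured compounds named here, no measured step bears on this change, and the group that leaves is the only substituent on that five-membered ring of compound 2. Weakening toward the limit is expected; the step of a 2.2-fold higher number from compound 2 to compound 4 (0.35 log units; beyond the scatter) is an estimate only. For compound 4 the expected value is 50000 nM, estimated between 15000 nM and 150000 nM.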

Compound 4, half-maximal inhibitory concentration: > 100000 nM
Compound 4 gave a limit, no number (the forecaster's own chance of this, stated with the estimate: 40%); middle value at least 2.0-fold (0.30 log units) from the limit.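

In this assay, among these compounds, hydrogen in place of (((4-fluorophenyl)sulfonyl)amino)methyl on the five-membered aromatic ring gives an at least 4.4-fold higher number from compound 2 to compound 4 (0.64 log units; beyond the scatter), the first readable step. On these data alone, compound 4 stands at > 100000 nM, a limit of the assay and not a number, so the true size of the step stays unknown. A substituent on this carbon is therefore tied to compound 2 having a number at all.

Which part of the departing group matters remains open. An aminomethyl group or a carboxylic acid on the same carbon would help separate the contribution of the short link from that of the 4-fluorophenyl sulfonyl part.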